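Acetyl to tert-butyl: compound 3 to compound 4

The source may report more compounds than this note shows. Statements on the series, on what has been measured and on what is new or still open speak of the compounds shown alone.

For the measured compounds named here, in a functional assay on HeLa cells (Homo sapiens) for inhibition, read by CCK-8 assay, with a stated time of 48 h (a lower number here means a stronger inhibitor, a higher number a weaker inhibitor), compound 3 `COc1cc(-c2ccnc3cc(-c4ccc(C(C)=O)cc4)nn23)cc(OC)c1OC` gives 1810 nM, the highest of the three numbers so far. Compound 1 `COc1cc(-c2ccnc3cc(-c4ccccc4)nn23)cc(OC)c1OC` gives 458 nM, and compound 2 `COc1cc(-c2ccnc3cc(-c4ccc5c(ccn5C)c4)nn23)cc(OC)c1OC` gives 19 nM. Compound 4 `COc1cc(-c2ccnc3cc(-c4ccc(C(C)(C)C)cc4)nn23)cc(OC)c1OC` carries tert-butyl in place of acetyl on an aromatic carbon, para to a large group: tert-butyl in place of acetyl on an aromatic carbon. The closest measured step is a 4.0-fold higher number from compound 1 to compound 3 (0.60 log units; beyond the scatter), with acetyl in place of hydrogen. The step of a 95-fold higher number from compound 2 to compound 3 (1.98 log units; beyond the scatter) shows how far a change at this substituent can move the number. Going by the values given here, no tert-butyl compound has been measured, so only a modest gain is expected in this assay. The expected step is a 2.3-fold lower number from compound 3 to compound 4 (0.35 log units; beyond the scatter). For compound 4 the estimated value is 800 nM, with an expected range of 250 nM to 2500 nM.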

Compound 4, half-maximal inhibitory concentration: > 10000 nM
Compound 4: no number, only a limit; the forecaster's own chance of this, stated with the estimate: 2%; middle value at least 12-fold (1.09 log units) away from the limit.
By their numbers in this assay, from the lowest: compound 2; then compound 1; then compound 3. At a limit, above all of these: compound 4.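

In this assay, compound 4 gives a limit and not a number: the limit of > 10000 nM in this assay, at which 1 of the 4 values shown sits.

Acetyl was the only substituent at this place before, and tert-butyl, which has no carbonyl, also moves the number up, with an at least 21-fold higher number from compound 1 to compound 4 (1.33 log units; beyond the scatter) and an at least 5.5-fold higher number from compound 3 to compound 4 (0.74 log units; beyond the scatter). Against the indole of compound 2 the loss widens to an at least 520-fold higher number from compound 2 to compound 4 (2.72 log units; beyond the scatter).

As far as these compounds go, how far beyond the limit compound 4 lies stays open. Also open, from the compounds shown here alone, is whether a smaller group at this place, such as an amine or a methoxy group, stays close to compound 1.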